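Methylsulfanyl for Aminoamino on the Shared Pyrimidinone Core

A few compounds are considered here, and "the series" means these few. Any claim that something is new, unique, unknown or untested is made for them only; others in the source may bear on it.

Two compounds of this series carry numbers in a functional assay, with a stated time of 10 min; a higher number here means a weaker inhibitor, a lower number a stronger inhibitor. Compound 1, `COc1ccc(-c2nc(SC)n(C)c(=O)c2C#N)cc1`, gives 48 ug/mL in this assay. Compound 2, `CN(C)c1ccc(-c2nc(NN)n(C)c(=O)c2C#N)cc1`, gives 66 ug/mL in this assay. Those two numbers lie within the usual scatter of each other, so the data give no separation between compound 2 and compound 1, and compound 2 cannot be set apart from compound 1 on either side.

The next compound, compound 3, `CSc1nc(-c2ccc(N(C)C)cc2)c(C#N)c(=O)n1C`, differs from compound 2 in one place: methylsulfanyl in place of aminoamino on an aromatic carbon, the carbon sitting between two ring nitrogen atoms. Compound 3 thereby carries the same methylsulfanyl group as compound 1, while keeping the aryl substituent of compound 2. Going by the values given here, no step between two measured compounds isolates this change, so the expectation rests on the spread of the two values shown.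

The step from compound 2 to compound 3 is expected to be a 1.3-fold lower number from compound 2 to compound 3 (0.12 log units; within the scatter), that is, no change beyond the scatter. Compound 3 is estimated at 50 ug/mL, with a range from 25 ug/mL to 100 ug/mL in this assay.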

Compound 3, half-maximal inhibitory concentration: 84 ug/mL
Compound 3: the middle estimate sits 1.7-fold (0.23 log units) below what was measured; the range from low to high includes it.
By their numbers in this assay, from the lowest: compounds 1, 2 and 3 (each within the scatter of the next).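

On the aromatic carbon between two ring nitrogen atoms, a direct comparison in this assay is now available with the dimethylamino aryl substituent held constant: a 1.3-fold higher number from compound 2 to compound 3 (0.10 log units; within the scatter), so methylsulfanyl and aminoamino are not separated here, even though the hydrogen-bond donors of aminoamino leave with the exchange. With methylsulfanyl held constant, the aryl substituent can also be read as a single change, dimethylamino in place of methoxy on an aromatic carbon: a 1.8-fold higher number from compound 1 to compound 3 (0.24 log units; within the scatter), and this change likewise gives no separation in this assay. No accompanying measurement bears on the reason for either result.

As far as these compounds go, whether a group such as a simple amine, a carboxylic acid or a longer alkylsulfanyl chain on the same aromatic carbon would move the number beyond the scatter remains open, since methylsulfanyl and aminoamino span only a narrow set of groups at this position. From the compounds shown here alone, it is also open whether the methylsulfanyl and aminoamino exchange reads the same way with methoxy on the aryl ring, or whether a group such as a halogen or a carboxylic acid on that ring would separate from methoxy and dimethylamino.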